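Swapping the thiophene on a fused core: a repeated change

The source may report more compounds than this note shows. Statements on the series, on what has been measured and on what is new or still open speak of the compounds shown alone.

Measured so far in a functional assay on cells (Cancer cell lines, Homo sapiens) for inhibition; a higher number here means a weaker inhibitor of growth, a lower number a stronger inhibitor of growth:
compound 1 `Cc1cc(-c2nc3sc(C)cn3c2/C=N/NC(=N)N)c(C)s1` gives 3720 nM
compound 2 `Cc1cn2c(/C=N/NC(=N)N)c(-c3cccs3)nc2s1` gives 2570 nM
compound 3 `Cc1cc(-c2nc3n(c2/C=N/NC(=N)N)CCS3)c(C)s1` gives 13800 nM

Compound 3 has the highest of these three numbers; the difference between its core and the core of compound 1 is not broken down here. Compound 4 `N=C(N)N/N=C/c1c(-c2cccs2)nc2n1CCS2` is not yet measured. It differs from compound 3 by thiophen-2-yl in place of 2,5-dimethylthiophen-3-yl on an aromatic carbon. The same kind of change, (thiophen-2-yl in place of 2,5-dimethylthiophen-3-yl on an aromatic carbon), has already been measured: a 1.4-fold lower number from compound 1 to compound 2 (0.16 log units; within the scatter). The surroundings differ slightly, since in compound 3 the place is also two ring bonds from two ring atoms that each bear a fused ring. Because the step of a 1.4-fold lower number from compound 1 to compound 2 (0.16 log units; within the scatter) was small, compound 4 is expected to stay close to compound 3, with an estimated step of a 1.4-fold lower number from compound 3 to compound 4 (0.14 log units; within the scatter). Compound 4 is therefore estimated at 10000 nM, likely between 4000 nM and 25000 nM.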

Compound 4, concentration for 50% growth inhibition: 17400 nM
For compound 4 the middle estimate is 1.7-fold (0.24 log units) below the measured one; measured number inside the range.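

In this assay, putting thiophen-2-yl in place of 2,5-dimethylthiophen-3-yl on the core of compound 3 gives a 1.3-fold higher number from compound 3 to compound 4 (0.10 log units; within the scatter). Set beside the same swap on the core of compound 1, the two steps do not differ: the same change on two cores in this assay, a 1.4-fold lower number (0.16 log units; within the scatter) from compound 1 to compound 2 and a 1.3-fold higher number (0.10 log units; within the scatter) from compound 3 to compound 4, 1.8-fold (0.26 log units) apart, within the scatter of two such steps. In these two pairs, then, the swap carries from one core to the other as a step too small to tell from scatter, but two pairs cannot show that it would behave the same way on any further core.

From the compounds shown here alone, whether another group at this place, such as an amine, a carboxylic acid or a phenyl ring, would move the number beyond the scatter remains open on both cores.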